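The compounds below may be only part of what the source reports. "The series", "measured", "known", "first", "only" and "open" are said of these compounds alone.

In a functional assay (B cells) with Mus musculus as the target (on this read-out lower numbers stand for an effect already at smaller amounts and higher numbers for an effect only at larger amounts of compound), compound 1 `[N-]=[N+]=NCC(O)Cn1c(=O)n(C2OC(CO)[C@@H](O)[C@H]2O)c2nc(N)nc(O)c21` gives 39 uM, the second highest of the three numbers measured. Compound 3 `C=CCn1c(=O)n([C@H]2CO[C@@H](CO)C2)c2nc(N)nc(O)c21` gives 83 uM, a higher number that lies beyond the usual scatter. Compound 2 `C=CCn1c(=O)n(C2CN(CCCC)CC(CO)O2)c2nc(N)nc(O)c21` gives 5 uM, a lower number, and that gap lies well beyond the scatter. Compound 4 `Nc1nc(O)c2c(n1)n(C1OC(CO)[C@@H](O)[C@H]1O)c(=O)n2CC(O)CSc1ccccc1` is built like compound 1 except for one change: phenylsulfanyl in place of azido on a saturated chain carbon, two bonds along the chain from an oxygen on a saturated carbon. Among the measured compounds shown here, no measured pair of compounds shows this change on its own, so nothing here tells how large its effect is or in which direction it points. A small step toward a lower number, a 2.0-fold lower number from compound 1 to compound 4 (0.29 log units; within the scatter), is expected in this assay, with wide uncertainty. Compound 4 is therefore estimated at 20 uM in this assay, within a range from 5 uM to 80 uM.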

Compound 4, concentration for half-maximal effect: 142 uM
The estimate for compound 4 lay 7.1-fold (0.85 log units) below the measured number, outside the stated range (above it).
By their numbers in this assay, from the lowest: compound 2; then compound 1; then compounds 3 and 4 (each within the scatter of the next).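

Among the compounds shown here, this is the first direct pair for this place: in this assay, phenylsulfanyl in place of azido on the saturated chain carbon gives a 3.6-fold higher number from compound 1 to compound 4 (0.56 log units; beyond the scatter). The chain end is therefore not indifferent to what it carries, and this swap means more compound is needed for the same effect. Nothing measured here explains the rise. On these data alone, with a single pair, it remains open whether the sulfur or the aromatic ring drives the shift, which phenoxy could help separate. As far as these compounds go, how an amine or a carboxylic acid would behave here also remains open.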